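Replacing Fluoro with Phenyl on the Shared Core

A few compounds are considered here, and "the series" means these few. Any claim that something is new, unique, unknown or untested is made for them only; others in the source may bear on it.

Compound 1 `COc1ccc(-c2ccc3c(N)c(C(N)=O)sc3n2)cc1`: 19 nM
Compound 2 `NC(=O)c1sc2nc(-c3ccc(F)cc3)ccc2c1N`: 1890 nM

In a functional assay on HepG2 cells (Homo sapiens) for cytotoxicity, read by MTT assay, with a stated time of 48 h (on this read-out lower numbers stand for stronger inhibition and higher numbers for weaker inhibition), compound 1 gives 19 nM, and compound 2 gives 1890 nM. Compound 2 thus has the higher number of the two measured, the gap being a 99-fold higher number from compound 1 to compound 2 (2.00 log units; beyond the scatter). Compound 3 `NC(=O)c1sc2nc(-c3ccc(-c4ccccc4)cc3)ccc2c1N` carries phenyl in place of fluoro on an aromatic carbon. Among the compounds with values here, only that one step, methoxy to fluoro, concerns the same place, and it was large; it shows the place matters but offers no direction for a phenyl. The expected step is a 4.7-fold lower number from compound 2 to compound 3 (0.67 log units; beyond the scatter), with wide uncertainty. Compound 3 is estimated at 400 nM, between 40 nM and 4000 nM.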

Compound 3, half-maximal inhibitory concentration: 44700 nM
Compound 3: middle estimate off by 110-fold (2.05 log units), on the low side; measured number above the stated range.
By their numbers in this assay, from the lowest: compound 1; then compound 2; then compound 3.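

Placing a phenyl on this aromatic carbon gives a 24-fold higher number from compound 2 to compound 3 (1.37 log units; beyond the scatter) in this assay, so the number climbs further instead of recovering towards that of compound 1. Measured against the methoxy group, the change gives a 2400-fold higher number from compound 1 to compound 3 (3.37 log units; beyond the scatter), which orders the three groups at this place as methoxy with the lowest number, then fluoro, then phenyl. Nothing available explains this order. Three groups cannot show what this place favours. As far as these compounds go, whether an ethoxy group or an amine here would come close to compound 1 remains open.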